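The source may hold more compounds than are shown below. What is called first, only, known or untested is meant among the compounds shown, and "the series" means these compounds.

Compound 1 `CCCCCNC(=O)[C@H]1O[C@@H](n2cnc3c(N)ncnc32)[C@H](O)[C@@H]1O` gives 12 nM
Compound 2 `CCCCCCCCNC(=O)[C@H]1OC(n2cnc3c(N)ncnc32)[C@H](O)[C@@H]1O` gives 21 nM
Compound 3 `CCC(C)NC(=O)[C@H]1OC(n2cnc3c(N)ncnc32)[C@H](O)[C@@H]1O` gives 198 nM

In an assay on cell membranes for binding affinity to 2-oxoglutarate receptor 1 (Rattus norvegicus), read by radioligand binding (a lower number here means a stronger inhibitor, a higher number a weaker inhibitor), compound 3 stands with the highest number of the three measured compounds, meaning the weakest binding. Compound 4 `CC1CCCCC1NC(=O)[C@H]1OC(n2cnc3c(N)ncnc32)[C@H](O)[C@@H]1O` is the next compound to be considered; it differs from compound 3 by 2-methylcyclohexyl in place of sec-butyl on an amide-type nitrogen. For the measured compounds named here, the only measured step that bears on this change runs the other way in size: a 9.4-fold higher number from compound 2 to compound 3 (0.97 log units; beyond the scatter), so shrinking the group on the amide nitrogen from a long chain to sec-butyl weakened binding considerably, and compound 1 with a pentyl chain also sits at a low number. Compound 4 enlarges the group again, though as a ring rather than a chain, for which no measured comparison exists. A drop in the number is therefore expected, and the expected step is a 4.0-fold lower number from compound 3 to compound 4 (0.60 log units; beyond the scatter). Compound 4 is estimated at 50 nM, with a likely range from 15 nM to 200 nM.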

Compound 4, inhibition constant: 69.5 nM
Compound 4: middle estimate off by 1.4-fold (0.14 log units), on the low side, within the range that was stated.
By their numbers in this assay, from the lowest: compounds 1 and 2 (each within the scatter of the next); then compound 4; then compound 3.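

In this assay, the change at the amide-type nitrogen shows that the group there need not be an open chain for the number to fall: 2-methylcyclohexyl in place of sec-butyl gives a 2.8-fold lower number from compound 3 to compound 4 (0.45 log units; beyond the scatter). The ring does not match the long chain, however, as 2-methylcyclohexyl in place of octyl gives a 3.3-fold higher number from compound 2 to compound 4 (0.52 log units; beyond the scatter), so the order at this position is not set by the count of carbon atoms in the group alone. No supporting measurement is available to explain why the ring falls short of octyl yet improves on sec-butyl.

The compounds shown leave open what plain cyclohexyl, without the methyl, would give, and so whether the methyl contributes to the result. They also leave open how a cyclopentyl or phenyl ring, or a chain ending in an amine, would compare at this nitrogen.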